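Pyridin-2-yl in Place of Chloro on a Weak Hydrazone

The source may hold more compounds than are shown below. What is called first, only, known or untested is meant among the compounds shown, and "the series" means these compounds.

Compound 1 `Clc1ccc(/C=N/Nc2nc3ccccc3s2)cc1` stands only at a limit in a functional assay on HCT-8 cells (Homo sapiens) for cytotoxicity, read by MTT assay, with a stated time of 72 h; a lower number here means a stronger inhibitor, a higher number a weaker inhibitor: compound 1 gives > 17300 nM, a limit of the assay. Compound 2 `Clc1ccc(/C=N/Nc2nc3ccccc3s2)c(Cl)c1` also sits at a limit; in this assay compound 2 gives > 15500 nM. For the measured compounds named here, the step that the two limits leave unreadable from compound 1 to compound 2 is therefore unreadable because of the limit of > 15500 nM in this assay, at which 1 of the 2 values shown sits, and (the limit of > 17300 nM in this assay, at which 1 of the 2 values shown sits), and no measured step bears readably on the change to compound 3 `C(=N/Nc1nc2ccccc2s1)\c1ccc(-c2ccccn2)cc1`, which differs from compound 1 by pyridin-2-yl in place of chloro on an aromatic carbon. Compound 3 is expected to remain weak, estimated at 20000 nM with a range of 5000 nM to 60000 nM. The expected step that the limit leaves unreadable from compound 1 to compound 3 is thus small.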

Compound 3, half-maximal inhibitory concentration: > 15100 nM
Compound 3 gave a limit, no number; the forecaster's own chance of this, stated with the estimate: 65%; the middle value is on the limit's open side.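

In this assay compound 3 gives > 15100 nM, which is a limit. For the compounds shown here, compound 1 also stands at a limit, so no step from compound 1 to compound 3 can be read. From the compounds shown here alone, whether pyridin-2-yl in place of chloro changes the activity at all remains open.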